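The compounds below may be only part of what the source reports. "The series", "measured", "known", "first", "only" and "open" are said of these compounds alone.

Values so far in a physicochemical assay for lipophilicity, using the shake flask method, measured as octanol-water partition, at pH 7.4; on this read-out lower numbers stand for lower lipophilicity and higher numbers for higher lipophilicity:
- compound 1 `CC(=O)N[C@H]1[C@H]([C@@H](O)[C@H](O)CNC(=O)c2ccc(Cl)cc2)O[C@@](OCc2ccccc2)(C(=O)O)C[C@@H]1O` gives "not determined" (no result reported) and no number
- compound 2 `CC(=O)N[C@H]1[C@H]([C@@H](O)[C@H](O)CNC(=O)c2ccc(Cl)cc2)O[C@@](OCc2cccc(Cl)c2Cl)(C(=O)O)C[C@@H]1O` gives 0.53
- compound 3 `CC(=O)N[C@H]1[C@H]([C@@H](O)[C@H](O)CNC(=O)c2ccc(Cl)cc2)O[C@@](OCc2cccc(F)c2F)(C(=O)O)C[C@@H]1O` gives -0.27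

Among the measured compounds shown here, compound 3 holds the lower of the two numbers available, and compound 2 is its only numerical neighbour. For the measured compounds named here, the one measured step is a number 0.80 log units lower from compound 2 to compound 3 (beyond the scatter) with 2,3-difluorophenyl in place of 2,3-dichlorophenyl.

Compound 4 `O=C(CC1CCC1)N[C@H]1[C@H]([C@@H](O)[C@H](O)CNC(=O)c2ccc(Cl)cc2)O[C@@](OCc2cccc(F)c2F)(C(=O)O)C[C@@H]1O` keeps the 2,3-difluorophenyl group of compound 3 and changes another place: cyclobutyl in place of hydrogen on a saturated chain carbon bound to a carbonyl carbon which also reads as acetyl to (cyclobutylmethyl)carbonyl. Going by the values given here, no measured step covers this place, so a number 0.80 log units lower from compound 2 to compound 3 (beyond the scatter) serves only as a guide to size. The change enters carbon only, with no net charge, and a rise of similar size or slightly more is expected in this assay on that limited basis.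

The expected step is a number 1.07 log units higher from compound 3 to compound 4 (beyond the scatter) and remains an estimate.

For compound 4 the estimated value is 0.8 with an expected range from 0.2 to 1.4 until a measurement is available.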

Compound 4, distribution coefficient: 0.75
Compound 4: the middle estimate sits 0.05 log units above what was measured; measured number inside the range.
By their numbers in this assay, from the lowest: compound 3; then compounds 2 and 4 (each within the scatter of the next).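

Cyclobutyl in place of hydrogen on a saturated chain carbon bound to a carbonyl carbon gives a number 1.02 log units higher from compound 3 to compound 4 (beyond the scatter) in this assay. Among the compounds shown here, the earlier compounds offered a step only at the 2,3-difluorophenyl and 2,3-dichlorophenyl group, so this is the first reading at the acetyl group, and it shows that a change entering carbon only, with no net charge and no hydrogen-bond donors or acceptors, can move this read-out beyond the scatter. No supporting measurement bears on the reason for this step.

A single step at this place leaves open whether a longer chain, an amine or a carboxylic acid on the same carbon would move the read-out the same way. It also leaves open whether the step would keep its size with 2,3-dichlorophenyl in place of 2,3-difluorophenyl.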